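This account rests on a few compounds, and the source may have more. Where it says the series, first, only, none or still open, it means among the compounds named here.

Compound 1 `COc1ccc(OC)c(C(=O)/C=C/c2ccc(OC/C=C/c3ccccc3)cc2)c1`: 17300 nM
Compound 2 `COc1ccc(OC)c(C(=O)/C=C/c2ccc(OC(=O)/C=C/c3ccc(C)cc3)cc2)c1`: 29000 nM

Among the measured compounds shown here, only two numbers are available so far, both from a functional assay on Hep 3B2 cells (Homo sapiens) for cytotoxicity, read by MTT assay; a lower number here means a stronger inhibitor, a higher number a weaker inhibitor. There, compound 2 gives 29000 nM and compound 1 gives 17300 nM. These two values lie within the usual scatter of each other, so they do not separate the two compounds.

Compound 3 `COc1ccc(OC)c(C(=O)/C=C/c2ccc(OC(=O)/C=C/c3cc(OC)c(OC)c(OC)c3)cc2)c1` keeps the rest of compound 2 but carries 3,4,5-trimethoxyphenyl in place of 4-methylphenyl on a double-bonded chain carbon bound to a double-bonded chain carbon.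

For the measured compounds named here, no measured step shows what this swap does, so the expectation stays close to the value of compound 2, 29000 nM. The expected step is a 1.4-fold lower number from compound 2 to compound 3 (0.14 log units; within the scatter), which means no change beyond the scatter is anticipated. Compound 3 is expected to measure about 21000 nM, within an estimated range of 7000 nM to 50000 nM.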

Compound 3, half-maximal inhibitory concentration: 23200 nM
For compound 3 the middle estimate is 1.1-fold (0.04 log units) below the measured one; the range from low to high includes it.
By their numbers in this assay, from the lowest: compounds 1, 3 and 2 (each within the scatter of the next).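

In this assay, putting 3,4,5-trimethoxyphenyl in place of 4-methylphenyl on a double-bonded chain carbon bound to a double-bonded chain carbon gives a 1.3-fold lower number from compound 2 to compound 3 (0.10 log units; within the scatter). This is the only step shown between compounds that differ in one place, and it shows that a group with 12 heavy atoms and 3 hydrogen-bond acceptors can replace one with 7 heavy atoms and 0 acceptors without separating the two compounds in this read-out. No available evidence bears on this result.

Going by these compounds, it remains open whether a group of a different kind at this same place, such as an amine or a carboxylic acid, would give a number beyond the scatter of compound 2. A single step also cannot show how other aromatic groups would behave here.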